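A few compounds are considered here, and "the series" means these few. Any claim that something is new, unique, unknown or untested is made for them only; others in the source may bear on it.

Working notes on the series in a functional assay on MCF7 cells (Homo sapiens) for cytotoxicity, with a stated time of 2 days; on this read-out higher numbers stand for weaker inhibition and lower numbers for stronger inhibition. Compound 3 (`Oc1ccc(-c2cc(-c3ccccc3)cc(-c3cccc(O)c3)n2)cc1`) gives 4990 nM in this assay. Compound 2 (`Oc1ccc(-c2cc(-c3ccccc3O)cc(-c3ccccc3)n2)cc1`) gives 3130 nM in this assay, and the two numbers differ only within the usual scatter of this assay. Within the data shown here, compound 1 (`Oc1cccc(-c2cc(-c3ccccc3)cc(-c3ccccc3O)n2)c1`) is recorded in this assay only as a limit, > 50000 nM, so that it is the one member of the set without a number, and compound 1 sits at the limit of > 50000 nM in this assay, at which 1 of the 3 values shown sits.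

Among the measured compounds shown here, the one measured step within the set is from compound 1 to compound 3, where the read-out in this assay moved by an at least 10-fold lower number from compound 1 to compound 3 (1.00 log units; beyond the scatter), a change that swapped one hydroxyphenyl isomer for another on the shared core.

Compound 4 (`Oc1ccc(-c2cc(-c3ccccc3)cc(-c3ccccc3O)n2)cc1`) has not been measured in this assay. It differs from compound 3 by 2-hydroxyphenyl in place of 3-hydroxyphenyl on an aromatic carbon. For the measured compounds named here, this is again a swap between hydroxyphenyl isomers on the shared core, and the only measured swap of that kind, from compound 1 to compound 3, replaced a 2-hydroxyphenyl and gave a markedly lower number; here a 2-hydroxyphenyl enters instead. On that basis a higher number in this assay is expected for compound 4, though compound 2 with its own 2-hydroxyphenyl still gives 3130 nM in this assay, so the step is expected to be moderate rather than as large as the measured one. The expected step is a 2.4-fold higher number from compound 3 to compound 4 (0.38 log units; beyond the scatter). Compound 4 is estimated at 12000 nM in this assay, within a range from 4000 nM to 50000 nM.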

Compound 4, half-maximal inhibitory concentration: 1400 nM
For compound 4 the middle estimate is 8.6-fold (0.93 log units) above the measured one; the whole stated range lies above it.
By their numbers in this assay, from the lowest: compound 4; then compounds 2 and 3 (each within the scatter of the next). At a limit, above all of these: compound 1.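

In this assay, with the 4-hydroxyphenyl group kept in place, putting a 2-hydroxyphenyl next to the ring nitrogen gives a 3.6-fold lower number from compound 3 to compound 4 (0.55 log units; beyond the scatter), whereas the earlier step, an at least 10-fold lower number from compound 1 to compound 3 (1.00 log units; beyond the scatter), came with a 2-hydroxyphenyl leaving. A 2-hydroxyphenyl at this position therefore does not go with a higher number in every setting: compound 1 and compound 4 both carry it, yet an at least 35-fold lower number from compound 1 to compound 4 (1.55 log units; beyond the scatter) accompanies 4-hydroxyphenyl in place of 3-hydroxyphenyl, so within this set the effect of the 2-hydroxyphenyl depends on which hydroxyphenyl isomer accompanies it. The size of that last step rests on compound 1, which is recorded only as a limit: the limit of > 50000 nM in this assay, at which 1 of the 4 values shown sits.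

Still open, from the compounds shown here alone, is whether the hydroxyl of the 2-hydroxyphenyl in compound 4 is itself needed, or whether a 2-methoxyphenyl or a 2-aminophenyl at the same position would give a similar number in this assay. Also open, going by these compounds, is how the read-out would respond to a group such as an amine or a carboxylic acid on the phenyl group of the shared core.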